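Sulfur substituents: from compound 3 to compound 4

The compounds below may be only part of what the source reports. "The series", "measured", "known", "first", "only" and "open" are said of these compounds alone.

Three sulfur substituents on the shared core have been measured in a functional assay on HT cells (Homo sapiens) for antiproliferative activity, read by fluorescence, with a stated time of 72 h; a higher number here means a weaker inhibitor of growth, a lower number a stronger inhibitor of growth. Compound 1 `CC(C)c1n[nH]c2c(NCc3ccc(-c4ccccn4)cc3)nc(SCC3CNC(=O)O3)nc12` gives 80 nM. Compound 2 `CC(C)c1n[nH]c2c(NCc3ccc(-c4ccccn4)cc3)nc(SCC(C)(C)O)nc12` gives 507 nM, and compound 3 `CC(C)c1n[nH]c2c(NCc3ccc(-c4ccccn4)cc3)nc(SC3CCCCC3O)nc12` gives 636 nM.

Compound 3 sits with compound 2 at the upper end of these numbers, and the gap between them is a 1.3-fold higher number from compound 2 to compound 3 (0.10 log units; within the scatter). Compound 1 stands apart from both: the steps are an 8.0-fold higher number from compound 1 to compound 3 (0.90 log units; beyond the scatter) and a 6.3-fold higher number from compound 1 to compound 2 (0.80 log units; beyond the scatter).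

Compound 4 `CSCCSc1nc(NCc2ccc(-c3ccccn3)cc2)c2[nH]nc(C(C)C)c2n1` differs from compound 3 as follows: 2-(methylsulfanyl)ethyl in place of 2-hydroxycyclohexyl on a sulfur. Going by the values given here, no measured compound carries 2-(methylsulfanyl)ethyl, so no measured step covers this exchange directly. The two hydroxy-bearing substituents offer the closest comparison, and replacing one with the other gave no separation beyond the scatter, as a 1.3-fold higher number from compound 2 to compound 3 (0.10 log units; within the scatter) shows. Among the compounds with values here, only the 2-oxo-1,3-oxazolidin-5-yl group of compound 1 has given a clear shift, and it has no counterpart in compound 4.

A large move in this assay is therefore not expected, and the estimate leans only slightly towards a lower number. The expected change is a 1.6-fold lower number from compound 3 to compound 4 (0.20 log units; within the scatter), which would not be a step beyond the scatter. For compound 4 the estimated value is 400 nM, with an expected range of 130 nM to 1100 nM.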

Compound 4, concentration for 50% growth inhibition: 975 nM
Compound 4: the middle estimate sits 2.4-fold (0.39 log units) below what was measured; the measured number falls inside the stated range.
By their numbers in this assay, from the lowest: compound 1; then compounds 2, 3 and 4 (each within the scatter of the next).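

In this assay the position on the sulfur accepts a 2-(methylsulfanyl)ethyl group, with no ring and 0 hydrogen-bond donors, without a separation from the hydroxy-bearing substituents: a 1.5-fold higher number from compound 3 to compound 4 (0.19 log units; within the scatter) and a 1.9-fold higher number from compound 2 to compound 4 (0.28 log units; within the scatter) both leave compound 4 in one cluster with compound 2 and compound 3. A hydroxy group on the sulfur substituent is therefore not needed to stay in that cluster, and going from 7 heavy atoms to 4 in the exchange of 2-hydroxycyclohexyl does not open a gap beyond the scatter. Compound 1 stands clear of this substituent as well, with a 12-fold higher number from compound 1 to compound 4 (1.09 log units; beyond the scatter) as the step, so the 2-oxo-1,3-oxazolidin-5-yl group remains the only one of the four that separates from the rest, and nothing available bears on what lies behind these numbers.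

As far as these compounds go, whether the separation of compound 1 depends on the closed ring or would persist with an open-chain amide on the same saturated chain carbon remains open. Also open, from the compounds shown here alone, is how an amine, a carboxylic acid or a longer chain ending in methylsulfanyl would fall relative to this cluster.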